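A few compounds are considered here, and "the series" means these few. Any claim that something is new, unique, unknown or untested is made for them only; others in the source may bear on it.

Compound 1 `CCc1ccc(-c2nc3c(c(C)nn3-c3ccccc3)c(-c3ccccc3[N+](=O)[O-])c2C#N)cc1`: in an ADME assay on BJ cells (Homo sapiens) for cytotoxicity, with a stated time of 72 h (on this read-out higher numbers stand for an effect only at larger amounts of compound and lower numbers for an effect already at smaller amounts), compound 1 gives > 20000 nM, which is a limit of the assay and not a number.
Compound 2 `CCc1ccc(-c2nc3c(c(C)nn3-c3ccccc3)c(-c3ccccc3Cl)c2C#N)cc1`: in this assay compound 2 gives > 20000 nM, likewise a limit.
Compound 3 `CCc1ccc(-c2nc3c(c(C)nn3-c3ccccc3)c(-c3ccccc3C(F)(F)F)c2C#N)cc1`: in this assay compound 3 gives > 20000 nM, again a limit.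

Compound 2 thus stands where every value shown stands, at the limit of > 20000 nM in this assay, at which 3 of the 3 values shown sit. The three steps between the measured compounds, a step that the two limits leave unreadable from compound 1 to compound 2, a step that the two limits leave unreadable from compound 1 to compound 3 and a step that the two limits leave unreadable from compound 2 to compound 3, each run between two limits, and none of them has a readable size.

Compound 4 `C#Cc1ccccc1-c1c(C#N)c(-c2ccc(CC)cc2)nc2c1c(C)nn2-c1ccccc1` differs from compound 2 by ethynyl in place of chloro on an aromatic carbon. Within the data shown here, no measured step carries a readable size, and none involves an ethynyl group, so the only guidance is that the three measured compounds share a single limit. The step of a number no higher from compound 2 to compound 4 (the limit leaves the size open) is expected to stay within the usual scatter. In this assay compound 4 is expected to give 20000 nM, within 10000 nM to 40000 nM, most likely again reported only as a limit.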

Compound 4, half-maximal effective concentration: > 20000 nM
Compound 4 was reported as a limit; the forecaster's own chance of this, stated with the estimate: 80%; the middle value sits exactly at the limit.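

Compound 4 gives a limit of the assay and not a number, as do compound 1, compound 2 and compound 3, and none of the steps from these three to compound 4 can be read: the limit of > 20000 nM in this assay, at which 4 of the 4 values shown sit.

The compounds shown leave open whether nitro, chloro, trifluoromethyl and ethynyl differ at all in this assay, and at what concentration any of these compounds would show an effect.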